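Aryl amine variation in a cytotoxicity series

The source may hold more compounds than are shown below. What is called first, only, known or untested is meant among the compounds shown, and "the series" means these compounds.

Measured compounds:
compound 1, `CCCCCCNc1nc(SCc2ccc(C(F)(F)F)cc2)nc2ccccc12`, gives 20200 nM in a functional assay on MDA-MB-231 cells (Homo sapiens) for cytotoxicity, read by MTT assay, with a stated time of 72 h; on this read-out lower numbers stand for stronger inhibition and higher numbers for weaker inhibition
compound 2, `CCCCCCCCNc1nc(SCc2ccc(C(F)(F)F)cc2)nc2ccccc12`, gives 22300 nM in this assay
compound 3, `Cc1ccccc1Nc1nc(SCc2ccc(C(F)(F)F)cc2)nc2ccccc12`, gives 27100 nM in this assay

All three numbers lie close together. Compound 3 is reached from the two alkyl amines by the steps of a 1.3-fold higher number from compound 1 to compound 3 (0.13 log units; within the scatter) and a 1.2-fold higher number from compound 2 to compound 3 (0.08 log units; within the scatter), both within the scatter, and the alkyl pair itself differs by a 1.1-fold higher number from compound 1 to compound 2 (0.04 log units; within the scatter). On these numbers compound 3 cannot be set apart from compound 1 or compound 2.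

Compound 4, `FC(F)(F)c1ccc(CSc2nc(Nc3cccc(Cl)c3)c3ccccc3n2)cc1`, is not yet measured in this assay. It differs from compound 3 in one place: 3-chlorophenyl in place of 2-methylphenyl on a nitrogen on an aromatic ring. Among the measured compounds shown here, no measured step swaps one aryl group for another on that nitrogen; the steps that bear on the position are the alkyl-to-aryl swaps above, and they left the number unchanged beyond the scatter. Compound 4 is therefore expected to move by a 1.1-fold lower number from compound 3 to compound 4 (0.04 log units; within the scatter), that is, no step beyond the scatter in this assay. The estimate for compound 4 is 25000 nM, with a range from 10000 nM to 60000 nM.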

Compound 4, half-maximal inhibitory concentration: 18000 nM
For compound 4 the middle estimate is 1.4-fold (0.14 log units) above the measured one; low and high end bracket the measured number.
By their numbers in this assay, from the lowest: compounds 4, 1, 2 and 3 (each within the scatter of the next).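

In this assay the swap of one aryl group for another on this nitrogen, 3-chlorophenyl in place of 2-methylphenyl, gives a 1.5-fold lower number from compound 3 to compound 4 (0.18 log units; within the scatter) and so leaves the two aryl amines unseparated. The steps from the alkyl amines read the same way, with a 1.2-fold lower number from compound 2 to compound 4 (0.09 log units; within the scatter) and a 1.1-fold lower number from compound 1 to compound 4 (0.05 log units; within the scatter) as the outcomes, so hexyl, octyl, 2-methylphenyl and 3-chlorophenyl on this nitrogen cannot be told apart in this series. No measurement at hand gives a reason for this flat result.

The swap changes both the group on the ring and its printed ring position, and the compounds shown do not separate the two. From the compounds shown here alone, whether a phenyl carrying a carboxylic acid, or a chain ending in an amine, on this nitrogen would give a step beyond the scatter remains open.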